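The source may hold more compounds than are shown below. What is called first, only, known or untested is meant among the compounds shown, and "the series" means these compounds.

Compound 1 `O=C(CN(c1ncnc2c1ncn2C1CCCCO1)C1CC1)N[C@@H](CO)C(=O)OCc1ccccc1` is the strongest of three compounds tested in a functional assay on the whole organism (Tail, strain ICR) with Mus musculus as the target, in the tail flick test, with a stated time of 120 min, at a dose of 25 umol/kg by the oral route; a higher number here means a stronger effect of the compound at the dose given, a lower number a weaker effect: there compound 1 gives 29.2%. Compound 2 `O=C(CN(c1nc(Cl)nc2[nH]cnc12)C1CC1)N[C@@H](CC(=O)OCc1ccccc1)C(=O)OCc1ccccc1` gives 12.1% in this assay, and compound 3 `CSCC[C@H](NC(=O)CN(c1nc(Cl)nc2[nH]cnc12)C1CC1)C(=O)O` gives 5.67%, both gaps to compound 1 lying beyond the scatter. Compound 4 `CC(C)C[C@H](NC(=O)CN(c1ncnc2c1ncn2C1CCCCO1)C1CC1)C(=O)OCc1ccccc1` has not yet been measured. It is built from compound 1 by one change: isopropyl in place of hydroxy on a saturated chain carbon, two bonds along the chain from an amide-type nitrogen and a carbonyl carbon. Within the data shown here, no measured pair shows what this kind of change does, so the step from compound 1 to compound 4 is expected to stay small, probably a mild loss within or just beyond the scatter, a number 5.2 percentage points lower from compound 1 to compound 4 (within the scatter). Compound 4 is therefore estimated at 24%, with a plausible range from 10% to 42%.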

Compound 4, a percentage reported as activity, at one dose (the size of the read-out at that dose, not a potency): 12.8%
Estimate against measurement, compound 4: 11.2 percentage points above; low and high end bracket the measured number.
By their numbers in this assay, from the lowest: compounds 3, 2 and 4 (each within the scatter of the next); then compound 1.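

In this assay, among these compounds, replacing hydroxy with isopropyl on this saturated chain carbon gives a number 16.4 percentage points lower from compound 1 to compound 4 (beyond the scatter), the first single change that can be read. It shows that the number responds to what sits at this position, with the hydroxymethyl side chain of compound 1 ahead of the isobutyl side chain of compound 4. No measurement here explains why the number falls. From the compounds shown here alone, whether an amine or a carboxylic acid at this carbon would match compound 1 stays open, as does the effect of a longer chain ending in hydroxy.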